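The source may hold more compounds than are shown below. What is called first, only, known or untested is meant among the compounds shown, and "the series" means these compounds.

Measured to date in a functional assay on MOLT-4 cells (Homo sapiens) for cytotoxicity, with a stated time of 72 h; on this read-out higher numbers stand for weaker inhibition and lower numbers for stronger inhibition:
- compound 1, `Cc1ccc(/C=C2\CCC/C(=C\c3ccc([N+](=O)[O-])cc3)C2=O)cc1`: 8440 nM
- compound 2, `COc1ccc(/C=C2\CCC/C(=C\c3ccccc3[N+](=O)[O-])C2=O)cc1`: 8900 nM
- compound 3, `CN(C)c1ccc(/C=C2\CCC/C(=C\c3cccc([N+](=O)[O-])c3)C2=O)cc1`: 10900 nM

All three numbers in this assay fall inside the usual scatter of one another. Compound 2 sits in the middle of the set: compound 1 is the nearest to it and compound 3 the furthest, yet neither gap is large enough to separate compound 2 from either neighbour. Among the compounds with values here, the series so far therefore reads as flat, with the nitro-bearing ring shifted and the group on the other ring varied, without any of it moving the read-out.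

Compound 4, `O=C1/C(=C/c2ccccc2)CCC/C1=C\c1ccccc1[N+](=O)[O-]`, has not yet been measured in this assay. It differs from compound 2 by hydrogen in place of methoxy on an aromatic carbon.

Within the data shown here, no measured pair in the set shows the effect of removing a group from that ring, so the expectation rests on the flatness seen across compound 1, compound 2 and compound 3. On that basis the step of a 1.1-fold higher number from compound 2 to compound 4 (0.03 log units; within the scatter) is expected to be small, with no change beyond the scatter in either direction. Compound 4 is accordingly estimated at 9500 nM, with a range from 4000 nM to 22000 nM.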

Compound 4, half-maximal inhibitory concentration: 1480 nM
Compound 4: middle estimate off by 6.4-fold (0.81 log units), on the high side, and the stated range ends above it.
By their numbers in this assay, from the lowest: compound 4; then compounds 1, 2 and 3 (each within the scatter of the next).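

In this assay, within the data shown here, the exchange of 4-methoxyphenyl for phenyl gives a 6.0-fold lower number from compound 2 to compound 4 (0.78 log units; beyond the scatter), the first single-place step and one that lies beyond the scatter. The flat read-out of compounds 1, 2 and 3 came from compounds differing in more than one place, so it could not isolate the contribution of any one group; this pair shows that the read-out responds to the group on this aromatic carbon, para to a large group, at least with the nitro-bearing ring of compound 2 held fixed. The data shown offer no measurement that accounts for the lower number once methoxy is replaced by hydrogen.

On these data alone, it remains open whether the gain depends on losing methoxy specifically or would also follow from placing a hydroxy group, a fluorine atom or a carboxylic acid on the same carbon. As far as these compounds go, it is also open whether the same exchange would give a step of similar size with the nitro group placed as in compound 1 or compound 3, since a single pair cannot show how far this result carries across the series.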